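Shortening the acid chain of a sulfonamide thromboxane antagonist

The source may report more compounds than this note shows. Statements on the series, on what has been measured and on what is new or still open speak of the compounds shown alone.

Measured compounds:
compound 1, `Cc1ccc(S(=O)(=O)N[C@H]2CCC=C2CCCCOCC(=O)O)cc1`, 1900 nM
compound 2, `O=C(O)CC/C=C\CC1=CCC[C@@H]1NS(=O)(=O)c1ccc(Cl)c(Cl)c1`, 1900 nM
compound 3, `Cc1ccc(S(=O)(=O)N[C@H]2CCC=C2C/C=C\CCCC(=O)O)cc1`, 250 nM

In a functional assay on a cell-free system (plasma) for inhibition of thromboxane A2 receptor (Homo sapiens), read by turbidimetry (on this read-out lower numbers stand for stronger inhibition and higher numbers for weaker inhibition), compound 3 gives the lowest of the three numbers; both compound 1 and compound 2 stand beyond the scatter above it. Within the data shown here, the one step that can be followed in one place, a 7.6-fold lower number from compound 1 to compound 3 (0.88 log units; beyond the scatter), concerns the replacement of an ether-containing chain by the 5-carboxypent-1-en-1-yl chain and says nothing directly about how long that chain should be.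

Compound 4, `Cc1ccc(S(=O)(=O)N[C@H]2CCC=C2C/C=C\CCC(=O)O)cc1`, differs from compound 3 by carboxy in place of carboxymethyl on a saturated chain carbon, two bonds along the chain from a double-bonded chain carbon. Among the measured compounds shown here, no measured pair covers this change. For the measured compounds named here, the only hint comes from compound 2, which carries the 4-carboxybut-1-en-1-yl chain together with a different aryl group and gives 1900 nM in this assay, against 250 nM for compound 3; since two places differ, the two values only suggest that the shorter chain is not obviously favoured.

Compound 4 is therefore expected to show a 3.6-fold higher number from compound 3 to compound 4 (0.56 log units; beyond the scatter), with the direction uncertain. The estimate for compound 4 is 900 nM, within a range from 250 nM to 4000 nM.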

Compound 4, half-maximal inhibitory concentration: 1800 nM
Beside the measured number, compound 4's estimate is 2.0-fold (0.30 log units) below it, within the range that was stated.
By their numbers in this assay, from the lowest: compound 3; then compounds 4, 1 and 2 (each within the scatter of the next).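

In this assay the shortening of the chain now has a measured step of its own: a 7.2-fold higher number from compound 3 to compound 4 (0.86 log units; beyond the scatter) shows that carboxy in place of carboxymethyl, on a saturated chain carbon two bonds along the chain from a double-bonded chain carbon, is a change beyond the scatter that the shorter chain does not survive unharmed. With the 4-carboxybut-1-en-1-yl chain in place, a 1.1-fold lower number from compound 2 to compound 4 (0.02 log units; within the scatter) is within the scatter, so 4-methylphenyl in place of 3,4-dichlorophenyl on a sulfonyl sulfur gives no readable difference, and a 1.1-fold lower number from compound 1 to compound 4 (0.02 log units; within the scatter) also lies within the scatter, so the 4-carboxybut-1-en-1-yl and 3-(carboxymethoxy)propyl chains cannot be told apart here, although the 5-carboxypent-1-en-1-yl chain stood clear of the latter. No measurement is at hand that would explain these steps.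

The compounds shown leave open whether a longer chain, such as 6-carboxyhex-1-en-1-yl, would carry the trend further or reverse it. They also leave open how 3,4-dichlorophenyl on the sulfonyl sulfur behaves together with the 5-carboxypent-1-en-1-yl chain.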